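Chain substituent change on the shared core

The source may hold more compounds than are shown below. What is called first, only, known or untested is meant among the compounds shown, and "the series" means these compounds.

Measured values come from a functional assay on H4 cells for agonist activity at growth hormone secretagogue receptor type 1 (Homo sapiens), read by FLIPR; a higher number here means that more compound is needed for the effect, a lower number that less compound is needed:
- compound 1 `CC(C)(N)C(=O)N[C@H](COCc1ccccc1)c1nnnn1Cc1ccc(NS(C)(=O)=O)cc1` gives 259 nM
- compound 2 `CN(c1ccccc1CCCn1nnnc1[C@@H](COCc1ccccc1)NC(=O)C(C)(C)N)S(C)(=O)=O` gives 14 nM
- compound 3 `COC(=O)C(c1ccccc1)n1nnnc1[C@@H](COCc1ccccc1)NC(=O)C(C)(C)N` gives 20 nM

Compound 2 gives the lowest number of the three. Compound 3 stands nearest, and the gap between compound 2 and compound 3 lies within the scatter, so no order between those two can be claimed. Compound 1 lies furthest from compound 2, a gap well beyond the scatter.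

The next compound, compound 4 `CC(C)(N)C(=O)N[C@H](COCc1ccccc1)c1nnnn1CCCCC#N`, differs from compound 2 by cyanomethyl in place of 2-(methyl(methylsulfonyl)amino)phenyl on a saturated chain carbon, three bonds along the chain from an aromatic nitrogen. For the measured compounds named here, no measured pair isolates this change; among the measured compounds, the substituent on the saturated chain carbon carries an aromatic ring in every case, whereas compound 4 keeps only a short chain ending in a nitrile. With the aromatic group gone, a weaker result than compound 2 is expected, by a step beyond the scatter. For compound 4, a value of 150 nM is estimated, with a range from 40 nM to 600 nM, which amounts to an expected step of an 11-fold higher number from compound 2 to compound 4 (1.03 log units; beyond the scatter).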

Compound 4, half-maximal effective concentration: 35 nM
Compound 4: middle estimate off by 4.3-fold (0.63 log units), on the high side; the measured number lies below the stated range.
By their numbers in this assay, from the lowest: compounds 2, 3 and 4 (each within the scatter of the next, the first and the last beyond it); then compound 1.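

In this assay, an aromatic ring on the substituent is not needed at this position: the ring-free 4-cyanobutyl chain of compound 4 gives a 2.5-fold higher number from compound 2 to compound 4 (0.40 log units; beyond the scatter), a modest loss for cyanomethyl in place of 2-(methyl(methylsulfonyl)amino)phenyl on the chain, and a 1.8-fold higher number from compound 3 to compound 4 (0.24 log units; within the scatter) for 4-cyanobutyl in place of the methoxycarbonyl-bearing benzyl group on the aromatic nitrogen. Carrying an aromatic ring does not by itself give a low number, as 3-cyanopropyl in place of 4-(methanesulfonamido)phenyl gives a 7.4-fold lower number from compound 1 to compound 4 (0.87 log units; beyond the scatter). No supporting measurement bears on the reason for these steps.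

On these data alone, the role of the nitrile remains open. An amine or a carboxylic acid at the chain end, or a longer chain, would separate the end group from chain length.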